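The source may hold more compounds than are shown below. What is called first, only, known or untested is meant among the compounds shown, and "the series" means these compounds.

Compound 1 `COc1ccc(-c2ccc(-c3ccc(C(=N)N)o3)o2)cc1` is one of three compounds whose effect on cell growth was measured in a functional assay on KM12 cells (Homo sapiens) for inhibition, read by sulforhodamine B assay, with a stated time of 48 h; a lower number here means a stronger inhibitor of growth, a higher number a weaker inhibitor of growth. In this assay compound 1 gives 590 nM, the lowest number of the three. Compound 2 `N=C(N)c1ccc(-c2ccc(-c3ccc(Cl)cc3)s2)s1` gives 1690 nM, and compound 3 `N=C(N)c1ccc(-c2ccc(-c3cncc4ccccc34)s2)s1` gives 1510 nM. Both of these gaps to compound 1 lie beyond the usual scatter of repeated measurements, so compound 1 is the strongest growth inhibitor among the three measured compounds.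

Compound 4 `N=C(N)c1ccc(-c2ccc(-c3ccccc3)o2)o1` has not yet been measured. It differs from compound 1 in one place: hydrogen in place of methoxy on an aromatic carbon. Among the measured compounds shown here, no pair of measured compounds shows this change, and compounds 2 and 3 differ from compound 1 in several places at once, so the data give no direct guide to its size. Removing a small group of this kind is expected to cost little, and the step is expected to be a 1.5-fold higher number from compound 1 to compound 4 (0.18 log units; within the scatter), a modest weakening that may not clear the scatter. Compound 4 is therefore estimated at 900 nM, with a plausible range from 400 nM to 2000 nM.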

Compound 4, concentration for 50% growth inhibition: 2610 nM
The estimate for compound 4 lay 2.9-fold (0.46 log units) below the measured number, and the stated range ends below it.
By their numbers in this assay, from the lowest: compound 1; then compounds 3, 2 and 4 (each within the scatter of the next).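

Replacing the methoxy with hydrogen on the six-membered aromatic ring gives a 4.4-fold higher number from compound 1 to compound 4 (0.65 log units; beyond the scatter) in this assay. Among the compounds shown here, this is the first change in the set that can be read on its own, since only this one place differs, and it shows that what sits at this position, para to a large group, matters for growth inhibition. With the methoxy gone the compound is a clearly weaker inhibitor, and nothing at hand explains the size of this loss.

From the compounds shown here alone, whether another group at the same place, such as a hydroxyl, an ethoxy or an amine, would match the methoxy or go beyond it remains open. Also open, going by these compounds, is whether a step of this size would appear on the core of compound 2.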